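Changing the amide aryl group from compound 1 to compound 4

The source may hold more compounds than are shown below. What is called first, only, known or untested is meant among the compounds shown, and "the series" means these compounds.

Three compounds have been measured in an assay on isolated protein for inhibition of histone deacetylase 4 (Homo sapiens), with a stated time of 1 h; on this read-out higher numbers stand for weaker inhibition and lower numbers for stronger inhibition:
compound 1, `O=C(COc1ccc2cc(/C=C3/SC(=O)NC3=O)ccc2c1)Nc1cccc(F)n1`, gives 840 nM;
compound 2, `Cc1cc(Br)ccc1NC(=O)COc1ccc2cc(/C=C3/SC(=O)NC3=O)ccc2c1`, gives 550 nM;
compound 3, `O=C(COc1ccc2cc(/C=C3/SC(=O)NC3=O)ccc2c1)Nc1ccc(Cl)c(Cl)c1`, gives 5500 nM.

Among these three numbers compound 1 stands second highest. Its nearest neighbour is compound 2, reached by a 1.5-fold lower number from compound 1 to compound 2 (0.18 log units; within the scatter), and its furthest is compound 3, reached by a 6.5-fold higher number from compound 1 to compound 3 (0.82 log units; beyond the scatter). Between the other two the step is a 10-fold higher number from compound 2 to compound 3 (1.00 log units; beyond the scatter).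

Compound 4, `Cc1ccc(NC(=O)COc2ccc3cc(/C=C4/SC(=O)NC4=O)ccc3c2)cc1Cl`, has not yet been measured. It differs from compound 1 in one place: 3-chloro-4-methylphenyl in place of 6-fluoropyridin-2-yl on an amide-type nitrogen.

For the measured compounds named here, two measured steps bear on this change, both starting from compound 1 and both replacing the 6-fluoropyridin-2-yl group by a halogenated phenyl ring. The step to compound 2, which carries a bromine and a methyl, was a 1.5-fold lower number from compound 1 to compound 2 (0.18 log units; within the scatter) and stayed within the scatter; the step to compound 3, which carries two chlorines, was a 6.5-fold higher number from compound 1 to compound 3 (0.82 log units; beyond the scatter) and went modestly beyond it. The 3-chloro-4-methylphenyl group of compound 4 carries one chlorine and one methyl and so sits between these two cases. For compound 4 a step of a 1.7-fold higher number from compound 1 to compound 4 (0.22 log units; within the scatter) is therefore expected, a small rise that may or may not exceed the scatter. The estimate for compound 4 in this assay is 1400 nM, with a range from 500 nM to 4000 nM.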

Compound 4, half-maximal inhibitory concentration: 1100 nM
Compound 4: middle estimate off by 1.3-fold (0.10 log units), on the high side; low and high end bracket the measured number.
By their numbers in this assay, from the lowest: compounds 2, 1 and 4 (each within the scatter of the next); then compound 3.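

For the compounds shown here, the chloro-to-methyl swap is the first change here confined to a single substituent on the ring: methyl in place of chloro on an aromatic carbon gives a 5.0-fold lower number from compound 3 to compound 4 (0.70 log units; beyond the scatter) in this assay and ties the weak result of compound 3 to that one group rather than to the phenyl ring as a whole. The carbon-only ring of compound 4 also holds level with the 6-fluoropyridin-2-yl group, with a 1.3-fold higher number from compound 1 to compound 4 (0.12 log units; within the scatter) showing that the ring nitrogen and fluorine of compound 1 can be replaced without a change beyond the scatter. The two methyl-bearing phenyl rings are not separated either, as a 2.0-fold higher number from compound 2 to compound 4 (0.30 log units; within the scatter) shows, although compound 1 carries no methyl and so goes against any reading that a methyl is required.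

No measurement shown here gives a reason for these differences. On these data alone, it remains open whether a methoxy group or an amine in place of the methyl of compound 4 would keep this level of inhibition, and whether the same swap from chloro to methyl would have a similar effect on other aryl groups.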